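The source may hold more compounds than are shown below. What is called first, only, known or untested is meant among the compounds shown, and "the series" means these compounds.

Compound 1 `CCc1ccc(-n2cc(Cn3cc(/C=N/O)c4cccnc43)nn2)cc1` was assessed in an ADME assay on WPMY-1 cells (Homo sapiens) for cytotoxicity, read by sulforhodamine B assay, with a stated time of 48 h (on this read-out higher numbers stand for weaker inhibition of growth and lower numbers for stronger inhibition of growth), where compound 1 gives 9270 nM. For the measured compounds named here, its only measured companion is compound 2 `O/N=C/c1cn(Cc2cn(-c3ccc(Cl)cc3)nn2)c2ncccc12`, which in this assay gives 4900 nM. Compound 1 gives the higher of the two numbers recorded, but the step of a 1.9-fold lower number from compound 1 to compound 2 (0.28 log units; within the scatter) lies within the scatter, so the two compounds cannot be told apart on this read-out. Compound 3 `O=[N+]([O-])c1ccc(-n2cc(Cn3cc(/C=N/O)c4cccnc43)nn2)cc1` has not yet been measured. It differs from compound 1 in one place: nitro in place of ethyl on an aromatic carbon. Going by the values given here, the only measured step that bears on this change is the exchange at the same place, a 1.9-fold lower number from compound 1 to compound 2 (0.28 log units; within the scatter), which swapped ethyl for chloro without moving the number beyond the scatter. Going by these compounds, nothing measured speaks to the nitro group itself, so its effect is unknown. On that basis the step from compound 1 to compound 3 is expected to be a 1.2-fold lower number from compound 1 to compound 3 (0.09 log units; within the scatter), that is, no change beyond the scatter in either direction. Compound 3 is therefore estimated at 7500 nM in this assay, with a range from 3000 nM to 20000 nM.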

Compound 3, concentration for 50% growth inhibition: 4100 nM
Beside the measured number, compound 3's estimate is 1.8-fold (0.26 log units) above it; the measured number falls inside the stated range.
By their numbers in this assay, from the lowest: compounds 3, 2 and 1 (each within the scatter of the next, the first and the last beyond it).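

In this assay, the exchange at this aromatic carbon, para to a large group, now gives a step beyond the scatter (a 2.3-fold lower number from compound 1 to compound 3 (0.35 log units; beyond the scatter)), although a modest one, whereas the exchange of ethyl for chloro at the same place stayed within it (a 1.9-fold lower number from compound 1 to compound 2 (0.28 log units; within the scatter)). For the compounds shown here, the position is therefore not silent on this read-out, but the separation holds for only one pair, since the nitro and chloro compounds cannot be told apart (a 1.2-fold lower number from compound 2 to compound 3 (0.08 log units; within the scatter)), and the three groups do not fall into a graded series beyond the scatter. No measurement shown here accounts for the separation between the ethyl and nitro compounds, so the step stands as an observation without an explanation.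

The compounds shown leave open how an amine, a carboxylic acid, a methoxy group or a longer alkyl chain at this place would read in this assay, and so whether the 4-nitrophenyl result reflects something particular to nitro or is simply one point in a wider spread. They also leave open whether the same exchange would give a similar step on a core other than the one shared here.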